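The compounds below may be only part of what the source reports. "The series", "measured", "known", "first", "only" and "open" are said of these compounds alone.

Two quinone-bearing compounds share a carboxylic acid side chain with an amine link, and each has a partner in which that chain is shortened. Compound 1 `CC1=CCC[C@H]2[C@](C)(CC3=CC(=O)C=C(N[C@@H](CC(C)C)C(=O)O)C3=O)[C@@H](C)CC[C@]12C` carries a large bicyclic terpene core; in a functional assay on HeLa cells (Homo sapiens) for cytotoxicity, read by MTT assay, with a stated time of 72 h (on this read-out higher numbers stand for weaker inhibition and lower numbers for stronger inhibition), compound 1 gives 7720 nM. Compound 3 `CC1=CCC[C@H]2[C@](C)(CC3=CC(=O)C=C(N[C@@H](C)C(=O)O)C3=O)[C@@H](C)CC[C@]12C` keeps that core but, as described by hydrogen in place of isopropyl on a saturated chain carbon, two bonds along the chain from an amine nitrogen and a carbonyl carbon, has the shorter chain; in this assay compound 3 gives 11700 nM, a step of a 1.5-fold higher number from compound 1 to compound 3 (0.18 log units; within the scatter). Compound 2 `CC(C)C[C@H](NC1=CC(=O)C=C(C(C)(C)C)C1=O)C(=O)O` has a tert-butyl group on the quinone in place of the terpene core; the difference between the two cores is not broken down here. In this assay compound 2 gives 57200 nM, the highest of the three numbers. Compound 4 `C[C@H](NC1=CC(=O)C=C(C(C)(C)C)C1=O)C(=O)O` is related to compound 2 by hydrogen in place of isopropyl on a saturated chain carbon, two bonds along the chain from an amine nitrogen and a carbonyl carbon, the same change that relates compound 1 to compound 3. Because the step of a 1.5-fold higher number from compound 1 to compound 3 (0.18 log units; within the scatter) stayed within the scatter, the expectation for compound 4 is a similarly small step of a 1.3-fold higher number from compound 2 to compound 4 (0.12 log units; within the scatter) in this assay. On that single precedent, compound 4 is estimated at 75000 nM, with a plausible range from 35000 nM to 180000 nM.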

Compound 4, half-maximal inhibitory concentration: 89100 nM
For compound 4 the middle estimate is 1.2-fold (0.07 log units) below the measured one; the measured number falls inside the stated range.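

In this assay, putting hydrogen in place of isopropyl gives a 1.6-fold higher number from compound 2 to compound 4 (0.19 log units; within the scatter), so on this core the change leaves the number within the usual scatter of repeated measurements. Going by these compounds alone, the same change on the other core gives a step of matching size, so in this small set it carries from one core to the other without a visible difference: the same change on two cores in this assay, a 1.5-fold higher number (0.18 log units; within the scatter) from compound 1 to compound 3 and a 1.6-fold higher number (0.19 log units; within the scatter) from compound 2 to compound 4, 1.0-fold (0.01 log units) apart, within the scatter of two such steps This shows only that the two pairs agree in this one cell assay; since neither step rises above the scatter, it gives no real effect of the side chain to transfer, and two cores cannot establish a rule for the whole series.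

As far as these compounds go, it remains open whether a longer chain, a phenyl ring, an amine or a second carboxylic acid in place of isopropyl would move the number beyond the scatter. From the compounds shown here alone, it is also open whether an ester or amide in place of the carboxylic acid would change the picture on either core.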